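Urea to direct aryl amide: notes toward compound 4

A few compounds are considered here, and "the series" means these few. Any claim that something is new, unique, unknown or untested is made for them only; others in the source may bear on it.

Within the data shown here, compound 3 `O=C(Nc1ccc(Cl)cc1)Nc1c(C(O)(C(F)(F)F)C(F)(F)F)ccc2ccccc12` gives 276 nM in an assay on LtK cells with ATP-sensitive inward rectifier potassium channel 11 (Homo sapiens) as the target (on this read-out lower numbers stand for an effect already at smaller amounts and higher numbers for an effect only at larger amounts of compound), which places it second highest of the three numbers so far. Its nearer neighbour is compound 1 `CCC(=O)Nc1c(C(O)(C(F)(F)F)C(F)(F)F)ccc2ccccc12`, which gives 15 nM in this assay; the step reads an 18-fold higher number from compound 1 to compound 3 (1.26 log units; beyond the scatter). Its further neighbour is compound 2 `CCC(C)C(=O)Nc1c(C(O)(C(F)(F)F)C(F)(F)F)ccc2ccccc12`, which gives 177000 nM; here the step is a 640-fold lower number from compound 2 to compound 3 (2.81 log units; beyond the scatter). Within the two amides, the step of a 12000-fold higher number from compound 1 to compound 2 (4.07 log units; beyond the scatter) shows how strongly a change at the carbon bound to the carbonyl carbon can move the read-out.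

Compound 4 `O=C(Nc1c(C(O)(C(F)(F)F)C(F)(F)F)ccc2ccccc12)c1ccc(Cl)cc1` carries the change (4-chlorophenyl in place of (4-chlorophenyl)amino on a carbonyl carbon). Among the measured compounds shown here, no measured step removes an amide-type nitrogen from the carbonyl carbon, so nothing speaks directly to it. For the measured compounds named here, the steps that bear on it are those altering the group on the carbonyl carbon, and both were large, so a sizeable move in either direction cannot be excluded. Going by the values given here, with no direct precedent, the step is expected to be modest and the estimate is left close to the value of compound 3. Compound 4 is therefore estimated at 500 nM, within a range of 50 nM to 5000 nM, which means an expected step of a 1.8-fold higher number from compound 3 to compound 4 (0.26 log units; within the scatter).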

Compound 4, half-maximal effective concentration: 570 nM
Compound 4: the middle estimate sits 1.1-fold (0.06 log units) below what was measured; measured number inside the range.
By their numbers in this assay, from the lowest: compound 1; then compound 3; then compound 4; then compound 2.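

Taking the amide-type nitrogen out of the group on the carbonyl carbon costs little in this assay: a 2.1-fold higher number from compound 3 to compound 4 (0.31 log units; beyond the scatter) is a modest move, just beyond the usual scatter, so the (4-chlorophenyl)amino nitrogen and its hydrogen-bond donor are not essential for a number of this order in this pair. Compared with the aliphatic amides, the direct aryl amide behaves much like the urea, with a 310-fold lower number from compound 2 to compound 4 (2.49 log units; beyond the scatter) on one side and a 38-fold higher number from compound 1 to compound 4 (1.58 log units; beyond the scatter) on the other, so both groups bearing a 4-chlorophenyl ring fall between the ethyl and sec-butyl amides, and neither reaches the low number of compound 1. Nothing measured on these compounds gives a reason for any of these steps.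

The chlorine is the only ring substituent shown, so it remains unknown whether an unsubstituted phenyl, a 4-methoxyphenyl or a benzyl group on the carbonyl carbon would stay in this range. The very wide gap between ethyl and sec-butyl is also unresolved, since a methyl, n-propyl, isopropyl or cyclopropyl group could show where along that change the number climbs.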